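The source may report more compounds than this note shows. Statements on the series, on what has been measured and on what is new or still open speak of the compounds shown alone.

Working notes on the series. Compound 1 `Nc1ccc(Nc2nc3ccccc3nc2S(=O)(=O)c2ccccc2)cc1` is the parent; in a functional assay on A549 cells (Homo sapiens) for cytotoxicity, read by MTT assay, with a stated time of 72 h (on this read-out lower numbers stand for stronger inhibition and higher numbers for weaker inhibition), compound 1 gives 12900 nM. Compound 2 `Nc1cccc(Nc2nc3ccccc3nc2S(=O)(=O)c2ccccc2)c1` carries 3-aminophenyl in place of 4-aminophenyl on a nitrogen on an aromatic ring, and in this assay compound 2 gives 1590 nM, a step of an 8.1-fold lower number from compound 1 to compound 2 (0.91 log units; beyond the scatter). Compound 3 `COc1ccc(S(=O)(=O)c2nc3ccccc3nc2Nc2ccc(N)cc2)cc1` differs from compound 1 by methoxy in place of hydrogen on an aromatic carbon; in this assay compound 3 gives 2990 nM, a step of a 4.3-fold lower number from compound 1 to compound 3 (0.63 log units; beyond the scatter). The numbers of compound 2 and compound 3 lie within the scatter of each other.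

Compound 4 `COc1ccc(S(=O)(=O)c2nc3ccccc3nc2Nc2cccc(N)c2)cc1` has not yet been measured in this assay. It stands to compound 3 as compound 2 stands to compound 1, through (3-aminophenyl in place of 4-aminophenyl on a nitrogen on an aromatic ring); the place of the change reads the same in both pairs, so this is the same change, now made on the core of compound 3 rather than the core of compound 1. As far as these compounds go, whether the step of compound 1 to compound 2 carries over onto a core that already differs is untested here, so the expected step from compound 3 to compound 4 is set somewhat smaller than the earlier one: a 5.4-fold lower number from compound 3 to compound 4 (0.74 log units; beyond the scatter), resting on an 8.1-fold lower number from compound 1 to compound 2 (0.91 log units; beyond the scatter). For compound 4 in this assay the expected value is 550 nM, with a range from 200 nM to 1600 nM.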

Compound 4, half-maximal inhibitory concentration: 340 nM
Compound 4: middle estimate off by 1.6-fold (0.21 log units), on the high side; the measured number falls inside the stated range.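

The change to 3-aminophenyl, made on the methoxy-bearing core, gives an 8.8-fold lower number from compound 3 to compound 4 (0.94 log units; beyond the scatter) in this assay, and this step matches the earlier one on the core of compound 1: the same change on two cores in this assay, an 8.1-fold lower number (0.91 log units; beyond the scatter) from compound 1 to compound 2 and an 8.8-fold lower number (0.94 log units; beyond the scatter) from compound 3 to compound 4, 1.1-fold (0.03 log units) apart, within the scatter of two such steps The methoxy change, read on the 3-aminophenyl side, gives a 4.7-fold lower number from compound 2 to compound 4 (0.67 log units; beyond the scatter) and likewise holds on both cores: the same change on two cores in this assay, a 4.3-fold lower number (0.63 log units; beyond the scatter) from compound 1 to compound 3 and a 4.7-fold lower number (0.67 log units; beyond the scatter) from compound 2 to compound 4, 1.1-fold (0.03 log units) apart, within the scatter of two such steps Within these four compounds the two changes therefore carry over from one core to the other with no sign that either depends on the other, but this rests on a single square of compounds in one cell assay, and it shows neither that the steps would hold on a further core nor why either change shifts the number.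

Still open, as far as these compounds go, is whether a different group in place of methoxy, such as chloro or trifluoromethyl, would carry over in the same way. Also open, from the compounds shown here alone, is whether the step to 3-aminophenyl would survive if the amine were replaced by an acetamide or a dimethylamino group.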